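Swapping 4-nitrophenyl for furan-2-yl on the shared core

The compounds below may be only part of what the source reports. "The series", "measured", "known", "first", "only" and "open" are said of these compounds alone.

- compound 1 `COc1cccc(/C=C/C(=O)c2ccc(OC)c3c2OC(C)(C)C=C3)c1`: > 10000 nM (a limit)
- compound 2 `COc1ccc(C(=O)/C=C/c2ccc([N+](=O)[O-])cc2)c2c1C=CC(C)(C)O2`: 3730 nM

For the measured compounds named here, in a functional assay on HT-29 cells (Homo sapiens) for antiproliferative activity, read by MTT assay, with a stated time of 24 h (on this read-out lower numbers stand for stronger inhibition and higher numbers for weaker inhibition), compound 2 gives 3730 nM as the only true number so far. Compound 1 gives > 10000 nM and this is a limit of the assay.

Compound 3 `COc1ccc(C(=O)/C=C/c2ccco2)c2c1C=CC(C)(C)O2` keeps the shared core of compound 2 and changes one group: furan-2-yl in place of 4-nitrophenyl on a double-bonded chain carbon bound to a double-bonded chain carbon. Going by the values given here, one measured step bears on this place, namely an at least 2.6-fold lower number from compound 1 to compound 2 (0.42 log units; beyond the scatter) and it favoured the 4-nitrophenyl group that compound 3 gives up. Among the compounds with values here, no compound carrying furan-2-yl has been measured, and that step rests on a limit, so the expectation is loose. A modest move toward weaker inhibition is expected in this assay. For compound 3 the expected step is a 2.1-fold higher number from compound 2 to compound 3 (0.33 log units; beyond the scatter) and it points to higher numbers. The estimate for compound 3 is 8000 nM with an expected range from 3000 nM to 20000 nM as its ends.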

Compound 3, half-maximal inhibitory concentration: > 10000 nM
Compound 3: no number, only a limit; the forecaster's own chance of this, stated with the estimate: 40%; middle value at least 1.2-fold (0.09 log units) away from the limit.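

At a double-bonded chain carbon bound to a double-bonded chain carbon, furan-2-yl does not keep what 4-nitrophenyl gave in this assay, with an at least 2.6-fold higher number from compound 2 to compound 3 (0.42 log units; beyond the scatter). Compound 3 gives > 10000 nM, which is a limit of the assay and not a number. Of the three groups at this place, only 4-nitrophenyl now reads as a true number, and the comparison of compound 1 with compound 3 cannot be read: the limit of > 10000 nM in this assay, at which 2 of the 3 values shown sit.

The compounds shown leave open whether the nitro group or the phenyl ring carries the difference, and how far a plain phenyl group would hold the number of compound 2. Going by these compounds, how a 4-aminophenyl or a 4-carboxyphenyl group would read at this place also remains open.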